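The compounds below may be only part of what the source reports. "The series", "measured", "known", "first", "only" and "open" are said of these compounds alone.

Among the compounds with values here, compound 2 `N#Cc1ccc(O[C@H]2CN(S(=O)(=O)c3ccc(Cl)cc3Cl)C[C@H]2CO)cc1F` is the starting point, and in an assay on cells for antagonist activity at transient receptor potential cation channel subfamily V member 4 (Homo sapiens), read by FLIPR and calcium flux, with a stated time of 10 min (on this read-out higher numbers stand for weaker inhibition and lower numbers for stronger inhibition), compound 2 gives 50 nM; this is the only number it has, a further entry carrying no single number. Compound 1 `N#Cc1ccc(O[C@H]2CN(S(=O)(=O)c3ccc(Cl)cc3Cl)C[C@@]2(O)CO)cc1F` also bears a hydroxy, and in this assay compound 1 gives 2.5 nM; 4 nM (2 entries). The change to compound 3 `N#Cc1ccc(O[C@H]2CN(S(=O)(=O)c3ccc(Cl)cc3Cl)C[C@]2(O)CO)cc1F` is hydroxy in place of hydrogen on a saturated ring carbon, a hydroxy in place of hydrogen on a saturated ring carbon. Within the data shown here, no measured step matches it, so the expectation rests on compound 1 with 2.5 nM; 4 nM (2 entries) standing stronger than compound 2. Compound 3 is expected near 20 nM, within 4 nM to 120 nM. The step of a 2.5-fold lower number from compound 2 to compound 3 (0.40 log units; beyond the scatter) is expected to favour stronger inhibition, its size uncertain.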

Compound 3, half-maximal inhibitory concentration: 100 nM
Beside the measured number, compound 3's estimate is 5.0-fold (0.70 log units) below it, within the range that was stated.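

Hydroxy in place of hydrogen on this saturated ring carbon gives a 2.0-fold higher number from compound 2 to compound 3 (0.30 log units; within the scatter) in this assay, so, in the configuration drawn here, the change does not separate the two compounds beyond repeated measurement. Compound 1 carries the same hydroxy and gives 2.5 nM; 4 nM (2 entries), whereas compound 3 gives 100 nM. These values therefore follow the configuration at this carbon, not the presence of the hydroxy alone: the fact that compounds 1 and 3 differ only in the configuration as drawn

As far as these compounds go, whether a methoxy or an amine on this carbon would follow compound 1 or compound 3 stays open. So does why the configuration matters.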